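The source may hold more compounds than are shown below. What is called first, only, known or untested is meant among the compounds shown, and "the series" means these compounds.

Values in a functional assay on HCT-116 cells (Homo sapiens) for antiproliferative activity, read by MTT assay, with a stated time of 72 h (on this read-out higher numbers stand for weaker inhibition and lower numbers for stronger inhibition), for the measured compounds:

compound 1 `NC1=NC2(CCOCC2)N(OCCCOc2ccccc2)C(N)=N1`, 6010 nM
compound 2 `NC1=NC2(CCOCC2)N(OCCCOc2ccccc2Br)C(N)=N1`, 30 nM
compound 3 `NC1=NC2(CCSCC2)N(OCCCOc2ccccc2Br)C(N)=N1`, 1 nM

Compound 1 stands highest of the three, beyond the scatter against both others. The nearest is compound 2, a 200-fold lower number from compound 1 to compound 2 (2.30 log units; beyond the scatter). Within the data shown here, compound 3, which carries a different shared core, gives the lowest number of the three; no single-point step to compound 1 is available, and only the two values themselves can be compared.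

Compound 4 `NC1=NC2(CCOCC2)N(OCCCOc2cccc(Br)c2)C(N)=N1` differs from compound 1 by bromo in place of hydrogen on an aromatic carbon. Among the measured compounds shown here, the one measured step that bears on this is the step from compound 1 to compound 2, also bromo in place of hydrogen on an aromatic carbon of the same ring, though at a different carbon; it was large and pointed downward. Whether bromo meta to a large group carries the same weight as the bromo of compound 2 is not shown by any measured pair, so a downward step is expected in this assay, but its size is taken as uncertain and probably smaller. For compound 4 the expected outcome is a 10-fold lower number from compound 1 to compound 4 (1.00 log units; beyond the scatter), giving an estimated 600 nM with a range from 60 nM to 3000 nM.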

Compound 4, half-maximal inhibitory concentration: 40 nM
For compound 4 the middle estimate is 15-fold (1.18 log units) above the measured one; measured number outside the range, below it.
By their numbers in this assay, from the lowest: compound 3; then compounds 2 and 4 (each within the scatter of the next); then compound 1.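

In this assay, the large fall in the number is not confined to the bromo of compound 2: a bromo at this other carbon of the same ring, phenoxy to 3-bromophenoxy, gives a 150-fold lower number from compound 1 to compound 4 (2.18 log units; beyond the scatter). The two placements cannot be told apart on this read-out, since 3-bromophenyl in place of 2-bromophenyl gives a 1.3-fold higher number from compound 2 to compound 4 (0.12 log units; within the scatter), which lies within the scatter. No measurement offered here accounts for the effect of the bromo at either carbon.

Going by these compounds, it remains open whether chloro, methoxy or an amine at the same ring carbon would match bromo, or whether the effect depends on bromo itself. Also open, on these data alone, is how the 3-bromophenoxy group behaves on the core of compound 3.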